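The source may hold more compounds than are shown below. What is called first, only, known or untested is meant among the compounds shown, and "the series" means these compounds.

Working notes on the series. All compounds share one core, bearing an allyl group and a propoxy chain ending in an isopropylamine, and differ only at one aromatic carbon. Compound 1 `C=CCc1cc(C(=O)CCC)ccc1OCCCNC(C)C` gives 1 nM in an assay for inhibition of squalene synthase (Rattus norvegicus), using microsomes; a lower number here means a stronger inhibitor, a higher number a weaker inhibitor. Compound 2 `C=CCc1cc(OCCCC)ccc1OCCCNC(C)C` gives 0.6 nM in this assay; the step of a 1.7-fold lower number from compound 1 to compound 2 (0.22 log units; within the scatter). Compound 3 `C=CCc1cc(-c2ccccc2)ccc1OCCCNC(C)C` gives 0.004 nM in this assay, the lowest number of the three measured, the gaps being a 150-fold lower number from compound 2 to compound 3 (2.18 log units; beyond the scatter) and a 250-fold lower number from compound 1 to compound 3 (2.40 log units; beyond the scatter).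

Compound 4 `C=CCc1cc(NC(C)=O)ccc1OCCCNC(C)C` differs from compound 3 by acetamido in place of phenyl on an aromatic carbon. Within the data shown here, the steps that bear on this are those in which phenyl entered, a 250-fold lower number from compound 1 to compound 3 (2.40 log units; beyond the scatter) and a 150-fold lower number from compound 2 to compound 3 (2.18 log units; beyond the scatter), both large and in the same direction. Removing phenyl is therefore expected to reverse them, a large rise in the number in this assay. Among the measured compounds shown here, no measured compound carries a group with a hydrogen-bond donor at this carbon, so compounds 1 and 2 give only a rough anchor for acetamido. Compound 4 is expected to give 3 nM, within a range of 0.5 nM to 20 nM. The expected step is a 750-fold higher number from compound 3 to compound 4 (2.88 log units; beyond the scatter).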

Compound 4, half-maximal inhibitory concentration: 65 nM
The estimate for compound 4 lay 22-fold (1.34 log units) below the measured number; measured number outside the range, above it.
By their numbers in this assay, from the lowest: compound 3; then compounds 2 and 1 (each within the scatter of the next); then compound 4.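

In this assay this carbon proves sensitive in both directions: with a 16000-fold higher number from compound 3 to compound 4 (4.21 log units; beyond the scatter) spanning the series, compound 4 is the weakest of the four and compound 3 the strongest. Acetamido also separates from the groups that replaced phenyl earlier, with a 110-fold higher number from compound 2 to compound 4 (2.03 log units; beyond the scatter) and a 65-fold higher number from compound 1 to compound 4 (1.81 log units; beyond the scatter) in the same direction, so replacing phenyl does not always land at the level of compounds 1 and 2, which lie within the scatter of each other. Nothing measured accounts for the size of these steps.

Open, going by these compounds, is whether the amide hydrogen matters or the acetamido group as a whole, which a tertiary amide or a plain amine at this carbon would separate. Open too, on these data alone, is whether the low number of compound 3 needs an aromatic ring, which a cyclohexyl group would test.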